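Swapping diethylamino for pyrrolidin-1-yl on compound 2

The source may report more compounds than this note shows. Statements on the series, on what has been measured and on what is new or still open speak of the compounds shown alone.

Measured so far in a physicochemical assay for solubility, in phosphate buffer, with a stated time of 24 h, at pH 7.4 (on this read-out lower numbers stand for lower solubility and higher numbers for higher solubility), for three compounds:
- compound 1 `CN(C)CCCNc1nc(-c2[nH]c3ccccc3c2C=O)nc2ccccc12` at 41.1 ug/mL
- compound 2 `CCN(CC)CCCCNc1nc(-c2[nH]c3ccc(OC)cc3c2C=O)nc2ccccc12` at 65.9 ug/mL
- compound 3 `COc1ccc2[nH]c(-c3nc(NCCN4CCCC4)c4ccccc4n3)c(C=O)c2c1` at 56.4 ug/mL

Compound 2 at 65.9 ug/mL sits within the usual scatter of both compound 1 and compound 3, so these three numbers cannot be ranked. The compound still to be measured is compound 4 `COc1ccc2[nH]c(-c3nc(NCCCCN4CCCC4)c4ccccc4n3)c(C=O)c2c1` and it differs from compound 2 in one place (pyrrolidin-1-yl in place of diethylamino on a saturated chain carbon, four bonds along the chain from a nitrogen on an aromatic ring) with the chain itself left as it is.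

Among the compounds with values here, only one measured step bears on this change: a 1.2-fold lower number from compound 2 to compound 3 (0.07 log units; within the scatter) with pyrrolidin-1-yl in place of 2-(diethylamino)ethyl. That step removes a larger group than diethylamino, so it is only a loose guide, but it offers no sign of a large shift. The expected step in this assay is a 1.1-fold lower number from compound 2 to compound 4 (0.04 log units; within the scatter) and this estimate means no change beyond the scatter, in either direction. For compound 4 the expected value is 60 ug/mL with 35 ug/mL to 100 ug/mL as the estimated range.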

Compound 4, solubility: 73.3 ug/mL
Estimate against measurement, compound 4: 1.2-fold (0.09 log units) below; the range from low to high includes it.
By their numbers in this assay, from the lowest: compounds 1, 3, 2 and 4 (each within the scatter of the next).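

In this assay, the direct swap of diethylamino for pyrrolidin-1-yl, with the chain left as it is, gives a step that stays within the scatter (a 1.1-fold higher number from compound 2 to compound 4 (0.05 log units; within the scatter)). Within the data shown here, this is the first clean reading of this change, and at this position the ring form and the open form of the amine cannot be told apart. With the ring kept, 2-(pyrrolidin-1-yl)ethyl in place of pyrrolidin-1-yl also leaves the number within the scatter (a 1.3-fold higher number from compound 3 to compound 4 (0.11 log units; within the scatter)), so neither single change moves this read-out. No measurement shown explains these results.

Still open, going by these compounds, is whether a morpholine ring or a piperazine ring at the end of the chain would shift the number beyond the scatter. A carboxylic acid in place of the amine is equally untested by these compounds.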